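The source may report more compounds than this note shows. Statements on the series, on what has been measured and on what is new or still open speak of the compounds shown alone.

Measured compounds:
- compound 1, `CC1=CC[C@H](C(C)(C)NC(=S)NN)CC1`: 900 nM
- compound 2, `COc1ccc(/C=N/NC(=S)NC(C)(C)[C@H]2CC=C(C)CC2)cc1`: 31200 nM

In a functional assay on MCF7 cells (Homo sapiens) for inhibition, read by sulforhodamine B assay, with a stated time of 48 h (a higher number here means a weaker inhibitor of growth, a lower number a stronger inhibitor of growth), compound 1 gives 900 nM, the lowest of the two numbers recorded, while compound 2 gives 31200 nM, a number well beyond the scatter of repeated measurements above that of compound 1. Compound 2 carries an aryl-methylidene group on the outer nitrogen of the thiosemicarbazide; compound 1 keeps that nitrogen free. Going by the values given here, no single-site step between these two is set out, so the pair shows only that the two values stand far apart.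

Compound 3, `CC1=CC[C@H](C(C)(C)NC(=S)N/N=C/c2cccs2)CC1`, is the next compound to be examined. It differs from compound 1 as follows: a group of 7 heavy atoms (5 carbon, 1 nitrogen, 1 sulfur; one five-membered aromatic ring with 1 hetero atom) in place of one nitrogen atom, on an amide-type nitrogen. Among the compounds with values here, this change moves compound 3 toward the pattern seen in compound 2, and the only comparison in hand, compound 1 against compound 2, points to a much higher number once the free nitrogen is replaced. The step from compound 1 to compound 3 is therefore expected to be upward and beyond the scatter, to the weaker side, with a 17-fold higher number from compound 1 to compound 3 (1.22 log units; beyond the scatter). Compound 3 is estimated at 15000 nM, within a range of 3000 nM to 60000 nM.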

Compound 3, concentration for 50% growth inhibition: 4800 nM
Estimate against measurement, compound 3: 3.1-fold (0.49 log units) above; the measured number falls inside the stated range.
By their numbers in this assay, from the lowest: compound 1; then compound 3; then compound 2.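

In this assay, replacing the amino group on the amide-type nitrogen with the larger thiophene-bearing group now has a single-site reading, a 5.3-fold higher number from compound 1 to compound 3 (0.73 log units; beyond the scatter), so the free amino group compares favourably with this replacement. The group on the carbon with a double bond to nitrogen also changes the outcome: thiophen-2-yl in place of 4-methoxyphenyl gives a 6.5-fold lower number from compound 2 to compound 3 (0.81 log units; beyond the scatter), which shows that the size of the loss from the amino compound is not fixed but depends on what this carbon carries. Nothing measured here accounts for either step.

From the compounds shown here alone, it remains open whether a plain phenyl, a furan-2-yl or a pyridin-2-yl ring, or a simple methyl group, on that carbon would bring the number closer to that of compound 1 or closer to that of compound 2. Going by these compounds, it is also open whether a small group such as methyl or acetyl on the amide-type nitrogen, with no double bond to carbon, would keep the number of compound 1 or move it toward that of compound 3.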